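The source may report more compounds than this note shows. Statements on the series, on what has been measured and on what is new or still open speak of the compounds shown alone.

Within the data shown here, in a functional assay on A549 cells (Homo sapiens) for antiproliferative activity, read by MTT assay, with a stated time of 72 h (a lower number here means a stronger inhibitor, a higher number a weaker inhibitor), compound 2 (`COc1cc(-n2ncnc2-c2ccc(C)cc2)cc(OC)c1OC`) gives 1100 nM, the only number so far. Compound 1 (`COc1cc(-c2ncnn2-c2cccc(F)c2)cc(OC)c1OC`) reads > 10000 nM, which is a limit of the assay. Compound 3 (`COc1cc(-c2ncnn2-c2ccc(F)cc2)cc(OC)c1OC`) reads > 10000 nM, also a limit. Among the measured compounds shown here, the sole measured step is a step that the two limits leave unreadable from compound 1 to compound 3. It concerns a fluorophenyl on an aromatic nitrogen, not the group changed here, and offers no size to carry over.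

Compound 4 (`CCOc1ccc(-c2ncnn2-c2cc(OC)c(OC)c(OC)c2)cc1`) departs from compound 2 by one change, ethoxy in place of methyl on an aromatic carbon.

For the measured compounds named here, no measured step bears directly on this change. With compound 2 at 1100 nM as the only anchor, no step beyond the scatter is expected in this assay, with a slight lean towards a stronger inhibitor. The expected move is a 1.8-fold lower number from compound 2 to compound 4 (0.26 log units; within the scatter). Compound 4 is estimated at 600 nM, with an expected range of 60 nM to 5000 nM.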

Compound 4, half-maximal inhibitory concentration: 100 nM
Compound 4: the middle estimate sits 6.0-fold (0.78 log units) above what was measured; the measured number falls inside the stated range.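

In this assay, among these compounds, ethoxy in place of methyl on an aromatic carbon gives an 11-fold lower number from compound 2 to compound 4 (1.04 log units; beyond the scatter), the first readable step. This place, para to a large group on the six-membered aromatic ring of carbon only, is therefore not indifferent to its substituent, although a single pair cannot tell whether the step goes with the added oxygen, the hydrogen-bond acceptor counted with it or the extra carbon. Compound 2 and compound 4 are the only compounds shown with numbers, and the other values are limits of the assay: the limit of > 10000 nM in this assay, at which 2 of the 4 values shown sit.

On these data alone, whether a longer chain such as butoxy would extend or reverse this step remains open. So does the outcome for an amine or a carboxylic acid at the same place.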